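From hydroxy to chloro: one swap, one open question

The source may report more compounds than this note shows. Statements on the series, on what has been measured and on what is new or still open speak of the compounds shown alone.

Compound 1 `C/C=C/C(=O)N(Cc1ccc(OC)c(Br)c1)c1cc(OC)c(OC)c(OC)c1`: 2800 nM
Compound 2 `C/C=C/C(=O)N(Cc1ccc(OC)c(O)c1)c1cc(OC)c(OC)c(OC)c1`: 55 nM

Both numbers come from a functional assay on HCT-116 cells (Homo sapiens) for inhibition, read by MTT assay, with a stated time of 48 h (a higher number here means a weaker inhibitor, a lower number a stronger inhibitor), and compound 2 holds the lower of the two, which makes it the stronger inhibitor of this pair. Within the data shown here, only one step has been measured so far: a 51-fold lower number from compound 1 to compound 2 (1.71 log units; beyond the scatter) when hydroxy takes the place of bromo on an aromatic carbon, a large change. Among the measured compounds shown here, compound 3 `C/C=C/C(=O)N(Cc1ccc(OC)c(Cl)c1)c1cc(OC)c(OC)c(OC)c1` has no measurement yet. It differs from compound 2 in one place, with chloro in place of hydroxy on an aromatic carbon on an aromatic carbon, ortho to a methoxy group. Chloro and bromo are both halogens, so compound 3 is expected to sit closer to compound 1 at 2800 nM than to the hydroxy compound. For the measured compounds named here, no chloro compound has been measured, so this match remains uncertain. The expected change is a 36-fold higher number from compound 2 to compound 3 (1.56 log units; beyond the scatter) in the direction of a weaker inhibitor, large and beyond the scatter. Compound 3 is estimated at 2000 nM in this assay with an expected range from 500 nM to 8000 nM for a first measurement.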

Compound 3, half-maximal inhibitory concentration: 1420 nM
The estimate for compound 3 lay 1.4-fold (0.15 log units) above the measured number, and the stated range covers the measured number.
By their numbers in this assay, from the lowest: compound 2; then compounds 3 and 1 (each within the scatter of the next).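

A second halogen now shows that the weak result at this position does not belong to bromo alone: in this assay, chloro in place of hydroxy on this aromatic carbon, ortho to a methoxy group, also gives a large step (a 26-fold higher number from compound 2 to compound 3 (1.41 log units; beyond the scatter)). Chloro and bromo cannot be told apart here (a 2.0-fold lower number from compound 1 to compound 3 (0.29 log units; within the scatter)), so across these three compounds the two halogens read alike, and only compound 2, with its hydroxy, stands apart as the strongest inhibitor. Nothing at hand explains why the hydroxy compound differs so sharply from the two halogen compounds.

Going by these compounds, whether a low number requires hydroxy itself remains open, as does whether an amine or a carboxylic acid on the same aromatic carbon could also give one. On these data alone, it is also open whether the same gap between hydroxy and the halogens would appear if the neighbouring methoxy group were replaced by a longer chain such as ethoxy.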